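The source may report more compounds than this note shows. Statements on the series, on what has been measured and on what is new or still open speak of the compounds shown alone.

Measured compounds:
- compound 1, `CC1=C(C(=O)OC(C)(C)C)C(c2ccsc2)NC(=O)N1`, in an assay on membranes from CHO cells for displacement of a labelled ligand from adenosine receptor A1 (Homo sapiens), read by scintillation counting, with a stated time of 60 min, tested at 1 uM (on this read-out higher numbers stand for more inhibition at the one concentration tested (going by the name of the read-out) and lower numbers for less inhibition), compound 1 gives 15%
- compound 2, `CCCC(=O)C1=C(C)NC(=O)NC1c1ccsc1`, compound 2 gives 6%
- compound 3, `CC1=C(C(=O)OC2CCCCC2)C(c2ccoc2)NC(=O)N1`, compound 3 gives 15%

Compound 3 stands level with compound 1 at the digits shown, and the value of compound 2 lies within the usual scatter of both, so no ranking among the three can be drawn. Among the measured compounds shown here, the one step measured in one place, a number 9 percentage points lower from compound 1 to compound 2 (within the scatter), exchanges the group on the carbonyl carbon and does not touch the ring that changes here.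

Compound 4, `CC1=C(C(=O)OC2CCCCC2)C(c2ccsc2)NC(=O)N1`, is not yet measured. The change from compound 3 to compound 4 is thiophen-3-yl in place of furan-3-yl on a saturated ring carbon. For the measured compounds named here, no measured step isolates this exchange; compound 1 and compound 3 differ in two places and show the same number, which is all those two values tell. With nothing pointing to a shift, the expected step from compound 3 to compound 4 is no change at the digits printed from compound 3 to compound 4 (within the scatter), none beyond the scatter. Compound 4 is therefore estimated at 15%, expected to fall between 5% and 25%.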

Compound 4, a percentage reported as inhibition, at one concentration (the size of the read-out at that concentration, not a potency): 8%
Compound 4: middle estimate off by 7 percentage points, on the high side; the measured number falls inside the stated range.
By their numbers in this assay, from the lowest: compounds 2, 4, 1 and 3 (each within the scatter of the next).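

In this assay the exchange of furan-3-yl for thiophen-3-yl on the saturated ring carbon now has a step of its own, a number 7 percentage points lower from compound 3 to compound 4 (within the scatter), so these two rings cannot be told apart at this position. With thiophen-3-yl held in place, the changes on the carbonyl side read the same way: a number 7 percentage points lower from compound 1 to compound 4 (within the scatter) for cyclohexyl in place of tert-butyl, and a number 2 percentage points higher from compound 2 to compound 4 (within the scatter) for cyclohexyloxy in place of propyl, so neither change counts as a gain or a loss. Nothing measured here explains these numbers.

As far as these compounds go, what remains open is whether any group at this position can move the number beyond the scatter. A phenyl ring or a pyridine ring in place of thiophen-3-yl would be one way to find out.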